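A few compounds are considered here, and "the series" means these few. Any claim that something is new, unique, unknown or untested is made for them only; others in the source may bear on it.

Values in a functional assay on MCF7 cells (Homo sapiens) for antiproliferative activity, read by MTT assay, with a stated time of 72 h; on this read-out lower numbers stand for stronger inhibition and higher numbers for weaker inhibition:
Compound 1 `COc1cc(-n2cnc3ccc(-c4ccccc4Cl)cc32)cc(OC)c1OC`: > 10000 nM (a limit of the assay, not a number)
Compound 2 `COc1cc(-n2cnc3ccc(-c4ccc(C)cc4F)cc32)cc(OC)c1OC`: 56 nM
Compound 3 `COc1cc(-n2cnc3ccc(-c4ccccc4)cc32)cc(OC)c1OC`: 2290 nM

Of the two exact numbers, compound 3 holds the higher one. Compound 4 `COc1cc(-n2cnc3ccc(-c4cccc(C)c4C)cc32)cc(OC)c1OC` replaces its phenyl with 2,3-dimethylphenyl: 2,3-dimethylphenyl in place of phenyl on an aromatic carbon. Going by the values given here, two measured steps bear on this change, and they point opposite ways. The large one is a 41-fold higher number from compound 2 to compound 3 (1.61 log units; beyond the scatter), and the other, at least modest, is an at least 4.3-fold lower number from compound 1 to compound 3 (0.64 log units; beyond the scatter). Substituted phenyl groups therefore fall on both sides of compound 3, and neither matches the new group. In this assay, no step beyond the scatter is expected, though the uncertainty is wide. The expected step is a 1.3-fold higher number from compound 3 to compound 4 (0.12 log units; within the scatter). The estimate for compound 4 is 3000 nM, with an expected range of 500 nM to 10000 nM.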

Compound 4, half-maximal inhibitory concentration: 2150 nM
For compound 4 the middle estimate is 1.4-fold (0.14 log units) above the measured one; the measured number falls inside the stated range.
By their numbers in this assay, from the lowest: compound 2; then compounds 4 and 3 (each within the scatter of the next). At a limit, above all of these: compound 1.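

In this assay the step of a 1.1-fold lower number from compound 3 to compound 4 (0.03 log units; within the scatter) shows that 2,3-dimethylphenyl on this aromatic carbon leaves the number where phenyl has it. The low number of compound 2 is not shared, with a 38-fold higher number from compound 2 to compound 4 (1.58 log units; beyond the scatter) as the gap, so a substituted phenyl here does not by itself lower the number. The step of an at least 4.6-fold lower number from compound 1 to compound 4 (0.66 log units; beyond the scatter) rests on a limit: the limit of > 10000 nM in this assay, at which 1 of the 4 values shown sits.

Still open, from the compounds shown here alone, is whether the fluoro or the methyl of 2-fluoro-4-methylphenyl carries the low number of compound 2. Also open, going by these compounds, is how a phenyl bearing an amine or a carboxylic acid would read.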